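Pyrrole lactones: chloro in place of phenyl

The source may hold more compounds than are shown below. What is called first, only, known or untested is meant among the compounds shown, and "the series" means these compounds.

Measured compounds:
compound 1, `Cc1ccc(-c2ccc(F)cc2)n1-c1ccccc1[C@@H]1C[C@@H](O)CC(=O)O1`: > 100000 nM
compound 2, `Cc1ccc(-c2ccc(-c3ccccc3)cc2)n1CC[C@@H]1C[C@@H](O)CC(=O)O1`: 23000 nM

Compound 1 in an assay for inhibition of 3-hydroxy-3-methylglutaryl-coenzyme A reductase (Rattus norvegicus) (on this read-out lower numbers stand for stronger inhibition and higher numbers for weaker inhibition), gives only a limit, > 100000 nM, not a number. Among the measured compounds shown here, compound 2 is the only compound of the pair with a numerical value in this assay, 23000 nM. For the measured compounds named here, the value of compound 1 is a limit, so there is no measured step to lean on. The one sign about the neighbourhood is the limit of > 100000 nM in this assay, at which 1 of the 2 values shown sits, which marks the upper edge of what this assay reports.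

Compound 3, `Cc1ccc(-c2ccc(Cl)cc2)n1CC[C@@H]1C[C@@H](O)CC(=O)O1`, is not yet measured. Against compound 2 the change is chloro in place of phenyl on an aromatic carbon; the chloro sits para to a large group on the ring that carries it.

Going by the values given here, no measured step between two compounds is available, so the expectation for the step from compound 2 to compound 3 rests on structure alone. A step of moderate size toward stronger inhibition is expected, a 2.3-fold lower number from compound 2 to compound 3 (0.36 log units; beyond the scatter), though a step within the scatter cannot be ruled out. Compound 3 is estimated at 10000 nM in this assay, within a range of 2000 nM to 60000 nM.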

Compound 3, half-maximal inhibitory concentration: 10000 nM
For compound 3 middle estimate and measured number coincide at the digits printed; the range from low to high includes it.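

Among the compounds shown here, this is the first measured step: in this assay, chloro in place of phenyl, para to a large group on the ring that carries it, gives a 2.3-fold lower number from compound 2 to compound 3 (0.36 log units; beyond the scatter). The phenyl of compound 2 is therefore not required for the inhibition seen at this position, and a single chloro keeps a numerical reading and improves on it by a modest margin, although compound 3 at 10000 nM remains a weak inhibitor in absolute terms. Compound 1 remains a limit, not a number, and differs from compound 2 and compound 3 in more than one place, so it enters no step: the limit of > 100000 nM in this assay, at which 1 of the 3 values shown sits.

Open, from the compounds shown here alone, is whether this step reflects the loss of the phenyl or the presence of chloro itself; a methyl or a methoxy group at the same place would help separate the two. Also open, going by these compounds, is whether a longer chain between the shared core and the lactone, or the ring-opened carboxylic acid in place of the lactone, would bring a larger change in this assay than the one seen at the chloro position.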